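Dichlorophenyl variant of the oxazole amide series

This account rests on a few compounds, and the source may have more. Where it says the series, first, only, none or still open, it means among the compounds named here.

Measured so far:
compound 1, `O=C(c1oc(C(F)(F)F)nc1-c1ccccc1F)N1CCN(c2cccc(Cl)c2)CC1`: "not active" (no number reported)
compound 2, `Cc1nc(-c2ccccc2)c(C(=O)N2CCN(c3cccc(C(N)=O)c3)CC2)o1`: 71 nM
compound 3, `COc1cc(OC)cc(N2CCN(C(=O)c3onc(C)c3-c3ccc(F)cc3)CC2)c1`: 475 nM

In a functional assay on HL-60 cells (Homo sapiens) for inhibition, read by MTT assay, with a stated time of 72 h (on this read-out higher numbers stand for weaker inhibition and lower numbers for stronger inhibition), compound 2 gives 71 nM, the lowest number among the two compounds that return a number. Compound 3 gives 475 nM, a gap from compound 2 that lies beyond the usual scatter. Compound 1 is reported only as "not active" (no number reported), with no number behind it.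

Compound 4, `Cc1nc(-c2ccccc2)c(C(=O)N2CCN(c3cc(Cl)cc(Cl)c3)CC2)o1`, is not yet measured. It differs from compound 2 in one place:
3,5-dichlorophenyl in place of 3-carbamoylphenyl on an amine nitrogen in a ring
For the measured compounds named here, no step between measured compounds is available for this change; compound 1, which also carries a halogen on its phenyl ring, differs from compound 2 in several further places and gives no number, so it cannot anchor a step. Going by the values given here, compound 4 is expected to give a higher number than compound 2, a step of a 4.2-fold higher number from compound 2 to compound 4 (0.63 log units; beyond the scatter) that would reach beyond the scatter, since the one compound without the carbamoyl group that returns a number, compound 3, sits at 475 nM. The estimate for compound 4 in this assay is 300 nM, with a range from 80 nM to 1500 nM.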

Compound 4, half-maximal inhibitory concentration: 41.8 nM
Estimate against measurement, compound 4: 7.2-fold (0.86 log units) above, and the stated range ends above it.
By their numbers in this assay, from the lowest: compounds 4 and 2 (each within the scatter of the next); then compound 3.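

In this assay, 3,5-dichlorophenyl in place of 3-carbamoylphenyl on the amine nitrogen in the ring gives a 1.7-fold lower number from compound 2 to compound 4 (0.23 log units; within the scatter), so the two compounds cannot be told apart on this read-out. For the compounds shown here, this is the first single-place step, and it shows that this position can lose the carbamoyl group, with the hydrogen-bond donor and acceptor counted on it, and still return a number within the scatter of compound 2. No measured evidence bearing on this result is available.

From the compounds shown here alone, it remains open whether a phenyl ring carrying a single chlorine gives a number in the same range as the ring carrying two. The same question stands for a phenyl ring carrying a carboxylic acid or an aminomethyl group at this position on the shared core.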